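The source may report more compounds than this note shows. Statements on the series, on what has been measured and on what is new or still open speak of the compounds shown alone.

Compound 2 `CCc1cccc(C)c1-n1nncc1CN1C(=O)C2(C(C#N)=C(N)Oc3c(N)cc4nc5ccccc5nc4c32)c2ccccc21` in a functional assay on A549 cells (Homo sapiens) for antiproliferative activity, read by MTT assay, with a stated time of 48 h (a lower number here means a stronger inhibitor, a higher number a weaker inhibitor), gives > 50000 nM, which is a limit of the assay and not a number. Compound 1 `CCOc1ccccc1-n1nncc1CN1C(=O)C2(C(C#N)=C(N)Oc3c(N)cc4nc5ccccc5nc4c32)c2ccccc21` in this assay gives > 50000 nM, again a limit rather than a number. The step that the two limits leave unreadable from compound 1 to compound 2 has no readable size. Compound 3 `N#CC1=C(N)Oc2c(N)cc3nc4ccccc4nc3c2C12C(=O)N(Cc1cnnn1-c1ccc(Cl)cc1Cl)c1ccccc12` is not yet measured; against compound 2 it differs by 2,4-dichlorophenyl in place of 2-ethyl-6-methylphenyl on an aromatic nitrogen. Among the compounds with values here, the only measured step on this aromatic nitrogen, from compound 1 to compound 2, gives no size, and the evidence here is the limit of > 50000 nM in this assay, at which 2 of the 2 values shown sit. No direction can be expected from the exchange of aryl groups, and nothing in the two values shown suggests that this position moves the read-out away from the limit. Compound 3 is expected to sit at 50000 nM, with a range from 20000 nM to 100000 nM, most likely reported again only as a limit. The expected step of a number no higher from compound 2 to compound 3 (the limit leaves the size open) is no step beyond the scatter.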

Compound 3, half-maximal inhibitory concentration: > 50000 nM
Compound 3 was reported as a limit (the forecaster's own chance of this, stated with the estimate: 80%); the middle value sits exactly at the limit.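

Compound 3 gives > 50000 nM in this assay, again a limit of the assay and not a number. The steps linking compound 1, compound 2 and compound 3 therefore cannot be read. On these data alone, whether any aryl group on this aromatic nitrogen brings the read-out off the limit remains open.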